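Ring swap from compound 3 to compound 4

The compounds below may be only part of what the source reports. "The series", "measured", "known", "first", "only" and "open" are said of these compounds alone.

In an ADME assay (liver) for metabolic stability, with Liver microsome (Homo sapiens) as the target, using microsomes (on this read-out higher numbers stand for fast clearance and lower numbers for slow clearance), compound 3 (`Fc1ccccc1[C@H](Nc1nnc(-c2c[nH]c3ncccc23)o1)C1CC1`) gives 59 mL.min-1.g-1, compound 2 (`c1ccc([C@H](Nc2nnc(-c3c[nH]c4ncccc34)o2)C2CC2)cc1`) gives 56 mL.min-1.g-1 and compound 1 (`Fc1ccccc1CNc1nnc(-c2c[nH]c3ncccc23)o1`) gives 32 mL.min-1.g-1, all within the scatter of compound 3. Compound 4 (`Fc1ncccc1[C@H](Nc1nnc(-c2c[nH]c3ncccc23)o1)C1CC1`) carries 2-fluoropyridin-3-yl in place of 2-fluorophenyl on a saturated chain carbon bound to a nitrogen on an aromatic ring and a saturated ring carbon. Among the compounds with values here, two measured steps bear on this: a 1.1-fold higher number from compound 2 to compound 3 (0.02 log units; within the scatter) for fluoro in place of hydrogen, and a 1.8-fold higher number from compound 1 to compound 3 (0.27 log units; within the scatter) for cyclopropyl in place of hydrogen. Both lie within the scatter, and neither places a nitrogen in the aromatic ring, so this change has no direct measure. Only a small step within the scatter is expected, a 1.5-fold lower number from compound 3 to compound 4 (0.17 log units; within the scatter). For compound 4 the estimated value is 40 mL.min-1.g-1, with an expected range of 18 mL.min-1.g-1 to 75 mL.min-1.g-1.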

Compound 4, intrinsic clearance in microsomes: 21 mL.min-1.g-1
Compound 4: middle estimate off by 1.9-fold (0.28 log units), on the high side; the measured number falls inside the stated range.
By their numbers in this assay, from the lowest: compounds 4, 1, 2 and 3 (each within the scatter of the next, the first and the last beyond it).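

In this assay, within the data shown here, the swap from 2-fluorophenyl to 2-fluoropyridin-3-yl gives a 2.8-fold lower number from compound 3 to compound 4 (0.45 log units; beyond the scatter) and is the first step beyond the scatter, as the fluoro and cyclopropyl steps stayed within it. Starting from phenyl, the same ring gives a 2.7-fold lower number from compound 2 to compound 4 (0.43 log units; beyond the scatter) and so a step of similar size. Nothing available explains either step.

Open, as far as these compounds go, is whether an unfluorinated pyridin-3-yl would give a similar step. Also open, from the compounds shown here alone, is whether the step would hold on the chain of compound 1, without the cyclopropyl.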